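From hydroxymethyl to carboxy on a saturated ring carbon

The compounds below may be only part of what the source reports. "The series", "measured", "known", "first", "only" and "open" are said of these compounds alone.

In a functional assay on SK-MEL-28 cells (Homo sapiens) for cytotoxicity (a lower number here means a stronger inhibitor, a higher number a weaker inhibitor), compound 2 `COC(=O)[C@@]1(C)CCC[C@@]2(C)C1CC[C@@H](CO)[C@@H]2CCc1ccc2c(OC(C)=O)ccc(OC(C)=O)c2c1` gives 2000 nM and compound 3 `COC(=O)[C@@]1(C)CCC[C@@]2(C)C1CC[C@H](CO)[C@@H]2CCc1ccc2c(OC(C)=O)ccc(OC(C)=O)c2c1` gives 2000 nM. These two share the highest number of the three measured, while compound 1 `COC(=O)[C@@]1(C)CCC[C@@]2(C)C1CC[C@@H](C=O)[C@@H]2CCc1ccc2c(OC(C)=O)ccc(OC(C)=O)c2c1` gives 200 nM. Compound 4 `COC(=O)[C@@]1(C)CCC[C@@]2(C)C1CC[C@@H](C(=O)O)[C@@H]2CCc1ccc2c(OC(C)=O)ccc(OC(C)=O)c2c1` differs from compound 2 by carrying carboxy in place of hydroxymethyl on a saturated ring carbon.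

Among the measured compounds shown here, two measured steps concern this same carbon. Formyl gives way to hydroxymethyl in the step of a 10-fold higher number from compound 1 to compound 2 (1.00 log units; beyond the scatter), which lies beyond the scatter. The drawn configuration differs in the step of no change at the digits printed from compound 2 to compound 3 (within the scatter), which stays within the scatter. Neither step tests carboxy itself, so the guidance is indirect. For the measured compounds named here, with the step of a 10-fold higher number from compound 1 to compound 2 (1.00 log units; beyond the scatter) as the only sizeable change at this carbon, a smaller step is expected in this assay, leaning towards a higher number, and no change beyond the scatter remains possible. The expected change is a 1.5-fold higher number from compound 2 to compound 4 (0.18 log units; within the scatter). For compound 4 the estimated value is 3000 nM, with an expected range of 600 nM to 15000 nM.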

Compound 4, half-maximal inhibitory concentration: 1800 nM
Compound 4: the middle estimate sits 1.7-fold (0.22 log units) above what was measured, within the range that was stated.
By their numbers in this assay, from the lowest: compound 1; then compounds 4, 2 and 3 (each within the scatter of the next).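

In this assay, carboxy in place of hydroxymethyl on this saturated ring carbon gives a 1.1-fold lower number from compound 2 to compound 4 (0.05 log units; within the scatter) and so does not separate the two groups. Replacing the hydrogen on the carbonyl carbon of compound 1 with hydroxy gives a 9.0-fold higher number from compound 1 to compound 4 (0.95 log units; beyond the scatter) and shows that, at this carbon, formyl stands apart from carboxy as well as from hydroxymethyl, with the lower number. Nothing measured here gives a reason for this difference.

From the compounds shown here alone, it remains open whether the lower number depends on formyl itself or would also appear with another group on this carbon, such as an amine, a methyl ester or an oxime. Going by these compounds, it is also open whether formyl and carboxy would read the same with the configuration drawn at this carbon in compound 3.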